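The source may hold more compounds than are shown below. What is called first, only, known or untested is meant among the compounds shown, and "the series" means these compounds.

Working notes on the series. Among the measured compounds shown here, compound 1 `COc1ccc(C(=O)c2cc(OC)c(OC)c(OC)c2)cc1NC(=O)/C=C/c1ccc(OC)c(OC)c1` gives 2500 nM in a functional assay on HT-29 cells (Homo sapiens) for cytotoxicity, read by MTT assay, with a stated time of 72 h (a lower number here means a stronger inhibitor, a higher number a weaker inhibitor), the second highest of the three numbers so far; compound 2 `COc1cccc(/C=C/C(=O)Nc2cc(C(=O)c3cc(OC)c(OC)c(OC)c3)ccc2OC)c1` gives 1900 nM and compound 3 `COc1ccc(C(=O)c2cc(OC)c(OC)c(OC)c2)cc1NC(=O)/C=C/c1cccc(OC(F)(F)F)c1` gives 5200 nM. The step of a 1.3-fold lower number from compound 1 to compound 2 (0.12 log units; within the scatter) lies within the scatter, while a 2.1-fold higher number from compound 1 to compound 3 (0.32 log units; beyond the scatter) and a 2.7-fold higher number from compound 2 to compound 3 (0.44 log units; beyond the scatter) are modest and beyond it. Compound 4 `COc1ccc(C(=O)c2cc(OC)c(OC)c(OC)c2)cc1NC(=O)/C=C/c1ccc(F)c(F)c1` is unmeasured; it differs from compound 1 by 3,4-difluorophenyl in place of 3,4-dimethoxyphenyl on a double-bonded chain carbon bound to a double-bonded chain carbon. For the measured compounds named here, the only step that bears on this change is the exchange of the same 3,4-dimethoxyphenyl in compound 1, which gave a 2.1-fold higher number from compound 1 to compound 3 (0.32 log units; beyond the scatter); a step of similar size and direction is therefore expected here. Compound 4 is expected to give 4500 nM in this assay, with a range of 2000 nM to 10000 nM, that is an estimated 1.8-fold higher number from compound 1 to compound 4 (0.26 log units; within the scatter).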

Compound 4, half-maximal inhibitory concentration: 4200 nM
Beside the measured number, compound 4's estimate is 1.1-fold (0.03 log units) above it; low and high end bracket the measured number.
By their numbers in this assay, from the lowest: compounds 2, 1, 4 and 3 (each within the scatter of the next, the first and the last beyond it).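

Replacing 3,4-dimethoxyphenyl with 3,4-difluorophenyl on the double-bonded chain carbon in this assay gives a step within the scatter (a 1.7-fold higher number from compound 1 to compound 4 (0.23 log units; within the scatter)), so both methoxy groups can give way to fluorine without a change that can be separated from scatter. 3,4-Difluorophenyl cannot be told apart from 3-(trifluoromethoxy)phenyl (a 1.2-fold lower number from compound 3 to compound 4 (0.09 log units; within the scatter)), yet it stands beyond the scatter from 3-methoxyphenyl (a 2.2-fold higher number from compound 2 to compound 4 (0.34 log units; beyond the scatter)). No available measurement accounts for these steps. As far as these compounds go, whether an amine or a carboxylic acid on this phenyl ring would shift the number remains open.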